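The source may report more compounds than this note shows. Statements on the series, on what has been measured and on what is new or still open speak of the compounds shown alone.

Measured so far:
- compound 1 `CC1CC/C(=N\Nc2ccccc2)c2ncc(CC(=O)O)c(=O)n21`: 100 umol/kg
- compound 2 `CC1CC/C(=N\Nc2ccc(Cl)cc2)c2ncc(C(=O)O)c(=O)n21`: 0.5 umol/kg
- compound 3 `CCOc1ccc(N/N=C2\CC[C@@H](C)n3c2ncc(C(=O)O)c3=O)cc1`: 0.2 umol/kg

In a functional assay on the whole organism for inhibition, with Rattus norvegicus as the target (a lower number here means that less compound is needed, a higher number that more compound is needed for the effect), compound 2 gives 0.5 umol/kg, the second highest of the three numbers. Its nearest neighbour is compound 3, whose number in this assay is lower, a gap that lies beyond the scatter; compound 1 lies furthest away, with a much higher number that is also beyond the scatter. Compound 1 also differs from the other two in the acid-bearing group on the shared core, so the pair of compounds 2 and 3 is the closer comparison for what follows.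

Compound 4 `CC1CC/C(=N\Nc2ccc(C3CC3)cc2)c2ncc(C(=O)O)c(=O)n21` has not yet been measured in this assay. It differs from compound 2 in one place: cyclopropyl in place of chloro on an aromatic carbon. Within the data shown here, no step between measured compounds shows this exact change, and the two measured para-substituted analogues, compound 2 and compound 3, lie close to each other. The step from compound 2 to compound 4 is therefore expected to be small, a 1.3-fold lower number from compound 2 to compound 4 (0.10 log units; within the scatter), and may well fall within the scatter. Compound 4 is estimated to give about 0.4 umol/kg in this assay, with a range from 0.12 umol/kg to 1.5 umol/kg.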

Compound 4, dose for 50% inhibition: 41.1 umol/kg
For compound 4 the middle estimate is 100-fold (2.01 log units) below the measured one; measured number above the stated range.
By their numbers in this assay, from the lowest: compound 3; then compound 2; then compound 4; then compound 1.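

In this assay, putting cyclopropyl in place of chloro on this aromatic carbon, para to a large group, gives an 82-fold higher number from compound 2 to compound 4 (1.91 log units; beyond the scatter), so the position is far from indifferent to what it carries. Among these compounds, this is the first step that changes one place alone, and it shows that this single exchange can move the number by a large amount, even though no hydrogen-bond donors or acceptors enter or leave. Nothing in the data presented explains the size of this step.

The exchange swaps one heavy atom for three and adds a ring, and the compounds shown do not separate these two features. From the compounds shown here alone, whether methyl, fluoro or an open-chain isopropyl at this place would stay near compound 2 or near compound 4 remains open.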